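This account rests on a few compounds, and the source may have more. Where it says the series, first, only, none or still open, it means among the compounds named here.

Compound 1, `COc1ccc(/C=C\C(=O)O)c(OCc2cn(-c3ccccc3)nn2)c1CC=C(C)C`: in a functional assay on NCI-H322 cells (Homo sapiens) for cytotoxicity, read by MTT assay, with a stated time of 24 h (on this read-out higher numbers stand for weaker inhibition and lower numbers for stronger inhibition), compound 1 gives 29200 nM.
Compound 2, `COc1ccc(/C=C\C(=O)O)c(OCc2cn(-c3ccc(NC(C)=O)cc3)nn2)c1CC=C(C)C`: compound 2 gives 45700 nM.

Compound 2 stands highest of the two numbers, with compound 1 nearest, though that gap lies within the scatter. Compound 3 is `COc1cccc(-n2cc(COc3c(/C=C\C(=O)O)ccc(OC)c3CC=C(C)C)nn2)c1`; it differs from compound 2 by 3-methoxyphenyl in place of 4-acetamidophenyl on an aromatic nitrogen. Within the data shown here, the only measured step that bears on this is a 1.6-fold higher number from compound 1 to compound 2 (0.19 log units; within the scatter), which concerned the acetamido group that now leaves. No step beyond the scatter is therefore expected in this assay. Compound 3 is expected to give 32000 nM, between 13000 nM and 80000 nM. The expected step is a 1.4-fold lower number from compound 2 to compound 3 (0.15 log units; within the scatter).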

Compound 3, half-maximal inhibitory concentration: 25200 nM
Beside the measured number, compound 3's estimate is 1.3-fold (0.10 log units) above it; the measured number falls inside the stated range.
By their numbers in this assay, from the lowest: compounds 3, 1 and 2 (each within the scatter of the next).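

In this assay, the place on the aromatic nitrogen accepts a substituted phenyl without acetamido: the change gives a 1.8-fold lower number from compound 2 to compound 3 (0.26 log units; within the scatter) and, set against the unsubstituted phenyl, methoxy gives a 1.2-fold lower number from compound 1 to compound 3 (0.06 log units; within the scatter) on the same scale. Neither step separates the compounds, so 3-methoxyphenyl, which has no hydrogen-bond donor, and 4-acetamidophenyl, which has one, cannot be told apart here. Nothing available explains these numbers.

The compounds shown leave open whether any group on this phenyl ring moves the number beyond the scatter. On these data alone, an amine or a carboxylic acid there remains untested in this account.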